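Phenyl for pyridin-3-yl on the shared core

A few compounds are considered here, and "the series" means these few. Any claim that something is new, unique, unknown or untested is made for them only; others in the source may bear on it.

Compound 1 `Oc1cccc(-c2cc(-c3cccnc3)nc(-c3cccc(Cl)c3)c2)c1` has "not determined" (no result reported) in an ADME assay on HEK293 cells (Homo sapiens) for cytotoxicity, read by CCK-8 assay and cell counting, with a stated time of 2 days; a higher number here means a weaker inhibitor, a lower number a stronger inhibitor; compound 2 `Oc1cccc(-c2cc(-c3cccnc3)nc(-c3ccccc3Cl)c2)c1` likewise has "not determined" (no result reported) in this assay, so compound 1 stands without a number in this series. Going by the values given here, the only value comes from compound 3 `Oc1ccc(-c2cc(-c3cccnc3)nc(-c3cccc(Cl)c3)c2)cc1`, which in this assay gives 25700 nM. Compound 4 `Oc1cccc(-c2cc(-c3ccccc3)nc(-c3cccc(Cl)c3)c2)c1` is not yet measured. It differs from compound 1 in one place: phenyl in place of pyridin-3-yl on an aromatic carbon. No step between measured compounds exists against which this change could be set, so the size of the move from compound 1 to compound 4 in this assay cannot be read from the numbers shown; no shift beyond the usual scatter is expected in either direction. Compound 4 is therefore estimated at about 25000 nM in this assay, between 8000 nM and 80000 nM, resting on compound 3 with its 25700 nM.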

Compound 4, half-maximal inhibitory concentration: 3120 nM
Estimate against measurement, compound 4: 8.0-fold (0.90 log units) above; the whole stated range lies above it.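

In this assay, going by these compounds alone, compound 1 has no single number, so no step to compound 4 can be read. Going by these compounds, what phenyl in place of pyridin-3-yl does on the shared core stays open. No evidence at hand bears on this result.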